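Trading a hydroxy for ethyl on the amide side chain

The compounds below may be only part of what the source reports. "The series", "measured", "known", "first", "only" and "open" are said of these compounds alone.

Measured compounds:
compound 1 `CCCCNC(=O)c1cc(OC)n(-c2ccccc2)n1`: 20.6%
compound 2 `CCCCOc1cc(C(N)=O)nn1-c1ccccc1`: 26.5%
compound 3 `CCCCOc1cc(C(=O)NCCO)nn1-c1ccccc1`: 61.2%

In a functional assay on the whole organism (strain Wistar) for inhibition, with Rattus norvegicus as the target, read by paw edema, with stated times of 30 min and 3 h, at a dose of 100 mg/kg by the oral route (a higher number here means more inhibition at the dose given (going by the name of the read-out), a lower number less inhibition), compound 3 stands highest of the three numbers. Its nearest neighbour is compound 2, whose value of 26.5% lies beyond the scatter below it, and the furthest is compound 1, at 20.6%. The one single-point step shown, a number 34.7 percentage points higher from compound 2 to compound 3 (beyond the scatter), is large and runs upward.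

Compound 4 `CCCCNC(=O)c1cc(OCCCC)n(-c2ccccc2)n1` differs from compound 3 in one place: ethyl in place of hydroxy on a saturated chain carbon, two bonds along the chain from an amide-type nitrogen. Seen one bond further out, this reads 2-hydroxyethyl to butyl on the amide nitrogen. Among the compounds with values here, no measured step covers this exchange directly. The step from compound 2 to compound 3 shows that what sits on the amide nitrogen matters greatly in this assay, and compound 1, which already carries a butylamide, gives a low number, though it also differs from compound 4 elsewhere, so its value alone cannot fix the outcome. Compound 4 is therefore expected to fall below compound 3, with a number 31.2 percentage points lower from compound 3 to compound 4 (beyond the scatter) as the estimated step. The estimated value for compound 4 is 30%, within a range of 15% to 50%.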

Compound 4, a percentage reported as inhibition, in the whole organism at one dose (the size of the read-out at that dose, not a potency): 43.3%
The estimate for compound 4 lay 13.3 percentage points below the measured number, within the range that was stated.
By their numbers in this assay, from the lowest: compounds 1 and 2 (each within the scatter of the next); then compound 4; then compound 3.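

In this assay, the ethyl-for-hydroxy exchange at this place, on a saturated chain carbon two bonds along the chain from an amide-type nitrogen, gives a number 17.9 percentage points lower from compound 3 to compound 4 (beyond the scatter), so the hydroxy-bearing side chain holds a real but modest lead over butyl. A butyl on the amide nitrogen still counts for something, with a number 16.8 percentage points higher from compound 2 to compound 4 (beyond the scatter), so the rise over the unsubstituted amide seen in a number 34.7 percentage points higher from compound 2 to compound 3 (beyond the scatter) does not belong to the 2-hydroxyethyl group alone. The low number of compound 1 also proves not to be set by its butylamide, since the change on the other side of the core, propyl in place of hydrogen on a saturated chain carbon bound to an oxygen on an aromatic ring, gives a number 22.7 percentage points higher from compound 1 to compound 4 (beyond the scatter).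

Nothing available here explains the difference between hydroxy and ethyl at this place. As far as these compounds go, it remains open whether an amine or a carboxylic acid at the end of the side chain, or a longer chain carrying the hydroxy, would match or pass compound 3 at 61.2%.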